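A few compounds are considered here, and "the series" means these few. Any claim that something is new, unique, unknown or untested is made for them only; others in the source may bear on it.

Measured so far:
Compound 1, `CSCC(=O)N1CCN(c2nc(=O)c3cc(C(F)(F)F)cc([N+](=O)[O-])c3s2)CC1`: in an ADME assay on Vero cells (Chlorocebus sabaeus) for cytotoxicity, read by MTT assay, with a stated time of 72 h (a higher number here means that more compound is tolerated, a lower number that less compound is tolerated), compound 1 gives > 125000 nM, which is a limit of the assay.
Compound 2, `CC(=O)N1CCN(c2nc(=O)c3cc(C(F)(F)F)cc([N+](=O)[O-])c3s2)CC1`: in this assay compound 2 gives > 125000 nM, again a limit.
Compound 3, `CC(C)(C)C(=O)N1CCN(c2nc(=O)c3cc(C(F)(F)F)cc([N+](=O)[O-])c3s2)CC1`: in this assay compound 3 gives > 125000 nM, also a limit.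

Compound 3 therefore stands only at a limit, and the two other values shown are limits too, so no ordering among the three can be read. The steps a step that the two limits leave unreadable from compound 1 to compound 2, a step that the two limits leave unreadable from compound 1 to compound 3 and a step that the two limits leave unreadable from compound 2 to compound 3 are all unreadable in size for the same reason; what they share is the limit of > 125000 nM in this assay, at which 3 of the 3 values shown sit.

The next compound, compound 4, `O=C(C1CCCCC1)N1CCN(c2nc(=O)c3cc(C(F)(F)F)cc([N+](=O)[O-])c3s2)CC1`, differs from compound 3 by cyclohexyl in place of tert-butyl on a carbonyl carbon. The amide substituent on the shared core has so far been varied without any of the three compounds reaching a measurable cytotoxic concentration, so the measured steps give no direction. The change from tert-butyl to cyclohexyl stays within the same kind of variation, and the step that the limit leaves unreadable from compound 3 to compound 4 is expected to be none beyond the scatter, most likely with the value again reported only as a limit.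

Compound 4 is thus estimated at 200000 nM in this assay, with a range from 80000 nM to 500000 nM.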

Compound 4, half-maximal cytotoxic concentration: 88700 nM
Compound 4: middle estimate off by 2.3-fold (0.35 log units), on the high side, and the stated range covers the measured number.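

In this assay compound 4 is the only compound shown that gives a number rather than a limit, so cyclohexyl on this carbonyl carbon, whose other neighbour is the ring amide nitrogen, places the series within the readable range of the assay. Cyclohexyl in place of tert-butyl gives an at least 1.4-fold lower number from compound 3 to compound 4 (0.14 log units; that floor lies within the scatter), cyclohexyl in place of methyl gives an at least 1.4-fold lower number from compound 2 to compound 4 (0.14 log units; that floor lies within the scatter), and cyclohexyl in place of (methylsulfanyl)methyl gives an at least 1.4-fold lower number from compound 1 to compound 4 (0.14 log units; that floor lies within the scatter), so each of these changes has a floor but no established size. The steps among compound 1, compound 2 and compound 3 cannot be read, and the true size of the steps to compound 4 stays open, because the other values all rest on one limit: the limit of > 125000 nM in this assay, at which 3 of the 4 values shown sit.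

From the compounds shown here alone, whether the measurable number belongs to cyclohexyl alone or extends to other carbon rings at this place remains open, and a cyclopentyl or phenyl ring on the carbonyl carbon would address that. Going by these compounds, how a longer chain, an amine or a carboxylic acid on the same carbonyl carbon would read in this assay also remains open.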